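A few compounds are considered here, and "the series" means these few. Any claim that something is new, unique, unknown or untested is made for them only; others in the source may bear on it.

In a functional assay on HUVEC cells (Homo sapiens) for antiproliferative activity, read by WST assay, with a stated time of 5 days (on this read-out lower numbers stand for stronger inhibition and higher numbers for weaker inhibition), compound 1 (`Cc1cc(C(=O)Nc2cc(Oc3ccc4nc(NC(=O)C5CC5)nn4c3)ccc2C)n(C)n1`) gives 1.3 nM, compound 2 (`Cc1cc(C(=O)Nc2cccc(Oc3ccc4nc(NC(=O)C5CC5)cn4c3)c2)n(C)n1`) gives 1.1 nM and compound 3 (`Cc1cc(C(=O)Nc2cc(Oc3ccc4nc(NC(=O)C5CC5)cn4c3)ccc2C)n(C)n1`) gives 0.8 nM. The number for compound 1 thus lies within the scatter of the other two, and the three cannot be ranked on these data.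

The next compound, compound 4 (`Cc1nc(C(=O)Nc2cc(Oc3ccc4nc(NC(=O)C5CC5)nn4c3)ccc2C)c(C)s1`), keeps the rest of compound 1 and changes one group: 2,5-dimethyl-1,3-thiazol-4-yl in place of 1,3-dimethyl-1H-pyrazol-5-yl on a carbonyl carbon. In words, 2,5-dimethyl-1,3-thiazol-4-yl stands in place of 1,3-dimethyl-1H-pyrazol-5-yl on a carbonyl carbon.

Within the data shown here, only one measured step is available, a 1.4-fold lower number from compound 2 to compound 3 (0.14 log units; within the scatter). It is a methyl in place of hydrogen on an aromatic carbon, so it says nothing directly about the group on the carbonyl carbon. Among the measured compounds shown here, all three measured compounds carry the same 1,3-dimethyl-1H-pyrazol-5-yl group, and no measured compound shows what replacing it does. The small size of that one step and the close grouping of the three values give no reason to predict a large shift, but they do not rule one out.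

The expected change is a 1.4-fold higher number from compound 1 to compound 4 (0.14 log units; within the scatter), which means no clear step beyond the scatter is anticipated, although the uncertainty is wide. For compound 4 the estimated value in this assay is 1.8 nM, with an expected range from 0.5 nM to 8 nM.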

Compound 4, half-maximal inhibitory concentration: 4.3 nM
For compound 4 the middle estimate is 2.4-fold (0.38 log units) below the measured one, within the range that was stated.
By their numbers in this assay, from the lowest: compounds 3, 2 and 1 (each within the scatter of the next); then compound 4.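

In this assay, the group on the carbonyl carbon proves able to move the number: 2,5-dimethyl-1,3-thiazol-4-yl in place of 1,3-dimethyl-1H-pyrazol-5-yl gives a 3.3-fold higher number from compound 1 to compound 4 (0.52 log units; beyond the scatter), a modest change and the only step shown that lies beyond the scatter. The two groups have the same counts of heavy atoms, hydrogen-bond donors and hydrogen-bond acceptors, each is one five-membered aromatic ring with 2 hetero atoms, and neither has a net charge, so these counts do not separate the two results. No measurement is available that explains the difference.

This single exchange, made on the core of compound 1, does not show whether the same replacement would have a similar effect on the core of compound 3. It also leaves open where a phenyl ring, a pyridine ring or a morpholine on the same carbonyl carbon would fall, and whether a thiazole without its two methyl groups would behave like the 2,5-dimethyl-1,3-thiazol-4-yl group.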